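Swapping Trifluoromethyl for Methoxy on a Short-Lived Compound

The compounds below may be only part of what the source reports. "The series", "measured", "known", "first", "only" and "open" are said of these compounds alone.

Compound 1 `Cc1oc(-c2ccccc2Cl)nc1CN1CCC(C(=O)NCCCN2C[C@H](C)C[C@H](C)C2)CC1`: 0.25 h
Compound 2 `Cc1oc(-c2c(Cl)cccc2C(F)(F)F)nc1CN1CCC(C(=O)NCCCN2C[C@H](C)C[C@H](C)C2)CC1`: 0.03 h

In an ADME assay on microsomes from liver (Rattus norvegicus) for metabolic stability, read by LC-MS, using NADPH, at 37 degrees C (on this read-out higher numbers stand for a longer-lived compound and lower numbers for a shorter-lived compound), compound 2 has the lower of the two numbers, 0.03 h, so it is the shorter-lived of the pair. Compound 3 `COc1cccc(Cl)c1-c1nc(CN2CCC(C(=O)NCCCN3C[C@H](C)C[C@H](C)C3)CC2)c(C)o1` has not yet been measured. It differs from compound 2 in one place: methoxy in place of trifluoromethyl on an aromatic carbon. In words, methoxy stands in place of trifluoromethyl on an aromatic carbon.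

For the measured compounds named here, one measured step bears on this change: an 8.3-fold lower number from compound 1 to compound 2 (0.92 log units; beyond the scatter). There, trifluoromethyl took the place of hydrogen on an aromatic carbon. Going by the values given here, that step shows what trifluoromethyl did in this pair, but no methoxy compound has been measured. Taking trifluoromethyl away may win back part of the drop, so a rise is expected, though a small one. For compound 3 the expected change is a 2.7-fold higher number from compound 2 to compound 3 (0.43 log units; beyond the scatter). Compound 3 is estimated at 0.08 h, with an expected range of 0.03 h to 0.2 h.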

Compound 3, half-life: 0.055 h
Beside the measured number, compound 3's estimate is 1.5-fold (0.16 log units) above it, within the range that was stated.
By their numbers in this assay, from the lowest: compounds 2 and 3 (each within the scatter of the next); then compound 1.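

In this assay, methoxy in place of trifluoromethyl gives a 1.8-fold higher number from compound 2 to compound 3 (0.26 log units; within the scatter), so at this place on the ring the two groups cannot be told apart. Set against hydrogen, methoxy gives a 4.5-fold lower number from compound 1 to compound 3 (0.66 log units; beyond the scatter), and trifluoromethyl gives an 8.3-fold lower number from compound 1 to compound 2 (0.92 log units; beyond the scatter), so among these three compounds the shorter half-life is not tied to trifluoromethyl alone: both substituted compounds differ from compound 1 by more than the scatter. Nothing measured here explains this shared drop.

Going by these compounds, it remains open whether a smaller group at this place, such as fluorine or methyl, would keep the half-life nearer to that of compound 1. Also open, on these data alone, is whether a group of a different kind, such as an amine or a hydroxyl, would behave like hydrogen or like methoxy and trifluoromethyl.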